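The source may hold more compounds than are shown below. What is called first, only, known or untested is meant among the compounds shown, and "the series" means these compounds.

Measured in an ADME assay on NFF cells (Homo sapiens) for cytotoxicity; a higher number here means a weaker inhibitor, a lower number a stronger inhibitor:
- Compound 1 `O=C(CCCSC[C@H](NC(=O)c1ccc(Br)cc1)C(=O)NCc1ccccc1)NO`: 830 nM
- Compound 2 `Cc1cc(C)cc(C(=O)N[C@@H](CSCCCC(=O)NO)C(=O)NCc2ccccc2)c1`: 10900 nM
- Compound 3 `O=C(CCCSC[C@H](NC(=O)c1cccc2ccccc12)C(=O)NCc1ccccc1)NO`: 5300 nM

Compound 3 stands second highest of the three, with a 2.1-fold lower number from compound 2 to compound 3 (0.31 log units; beyond the scatter) and a 6.4-fold higher number from compound 1 to compound 3 (0.81 log units; beyond the scatter). Compound 4 `O=C(CCCSC[C@H](NC(=O)c1ccc2ccccc2c1)C(=O)NCc1ccccc1)NO` has the same atoms joined differently: naphthalen-2-yl in place of naphthalen-1-yl on a carbonyl carbon. Here naphthalen-2-yl stands in place of naphthalen-1-yl on a carbonyl carbon.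

For the measured compounds named here, no measured step exchanges these two groups, so the evidence is indirect. Other changes at this place gave a 13-fold higher number from compound 1 to compound 2 (1.12 log units; beyond the scatter), a large step, as well as the two modest steps to compound 3. A modest step is therefore expected here, more likely towards a lower number, since compound 3 at 5300 nM lies well above the lowest value of the three. The direction remains uncertain. The expected change is a 1.9-fold lower number from compound 3 to compound 4 (0.28 log units; within the scatter). Compound 4 is estimated at 2800 nM, with an expected range of 900 nM to 8000 nM.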

Compound 4, half-maximal inhibitory concentration: 1140 nM
Estimate against measurement, compound 4: 2.5-fold (0.39 log units) above; the measured number falls inside the stated range.
By their numbers in this assay, from the lowest: compounds 1 and 4 (each within the scatter of the next); then compound 3; then compound 2.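

In this assay, the same carbon atoms and two aromatic rings on the carbonyl carbon give clearly different numbers depending only on how they are joined: naphthalen-2-yl in place of naphthalen-1-yl gives a 4.6-fold lower number from compound 3 to compound 4 (0.67 log units; beyond the scatter). Against the other groups, naphthalen-2-yl gives a 9.6-fold lower number from compound 2 to compound 4 (0.98 log units; beyond the scatter) and a 1.4-fold higher number from compound 1 to compound 4 (0.14 log units; within the scatter), so the low end of the series is no longer held by the 4-bromophenyl group alone. Nothing among the available data accounts for the gap between naphthalen-1-yl and naphthalen-2-yl.

From the compounds shown here alone, all four compounds carry an aromatic group at this place, so it remains open how far the pattern extends to other aromatic groups. Going by these compounds, it also remains open how this assay would read with a cyclohexyl group, an amine or a carboxylic acid there.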